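Removing the Aromatic Hydroxy Group from Compound 1

The source may hold more compounds than are shown below. What is called first, only, known or untested is meant among the compounds shown, and "the series" means these compounds.

In an assay on isolated protein for inhibition of tissue alpha-L-fucosidase (Bos taurus), tested at 1000 uM (on this read-out higher numbers stand for more inhibition at the one concentration tested (going by the name of the read-out) and lower numbers for less inhibition), compound 1 `OC[C@@]1(c2ccc(O)cc2)NC[C@@H](O)[C@@H]1O` gives 0%, level with compound 3 `OC[C@]1(c2ccc(O)cc2)NC[C@H](O)[C@H]1O`, which gives 0%; together these are the lowest of the three numbers recorded. Compound 2 `Cc1ccc([C@@]2(CO)NC[C@H](O)[C@H]2O)cc1` gives 3.3%. Two measured steps frame the question. The step of no change at the digits printed from compound 1 to compound 3 (within the scatter) compares mirror images, as the fact that compounds 1 and 3 differ only in the configuration as drawn shows, and leaves the read-out unmoved. The step of a number 3.3 percentage points lower from compound 2 to compound 3 (within the scatter), which swaps a methyl for a hydroxy on the same aromatic carbon, also stays within the scatter. Compound 4 `OC[C@@]1(c2ccccc2)NC[C@@H](O)[C@@H]1O` differs from compound 1 by hydrogen in place of hydroxy on an aromatic carbon. Since neither the inversion of all stereocentres nor the exchange of methyl for hydroxy on this ring shifted this assay beyond its scatter, the loss of the hydroxy group is expected to produce no step beyond the scatter either. Compound 4 is therefore estimated at 1%, within 0% to 10%, an expected step of a number 1 percentage points higher from compound 1 to compound 4 (within the scatter).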

Compound 4, a percentage reported as inhibition, at one concentration (the size of the read-out at that concentration, not a potency): 0%
Estimate against measurement, compound 4: 1 percentage points above; the range from low to high includes it.
By their numbers in this assay, from the lowest: compounds 1, 3, 4 and 2 (each within the scatter of the next).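

In this assay, within the data shown here, the change gives no change at the digits printed from compound 1 to compound 4 (within the scatter) and so provides the first direct comparison of hydroxy with hydrogen at this position, on the aromatic carbon para to a group of 9 heavy atoms. Compound 1 gives 0% and compound 4 gives 0%, so the hydroxy makes no contribution that this read-out registers, although a loss could not have shown with compound 1 already at this level. No available evidence bears on why the number stays where it is.

The compounds shown leave open whether an amine, a carboxylic acid or a methoxy group at this position would move the number in this assay at all. Also open, going by these compounds, is how hydrogen at this position reads in the mirror-image series of compound 3, where only hydroxy and methyl appear.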